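Anilino Replaced by Methylsulfanyl: Expected Inhibition

The source may hold more compounds than are shown below. What is called first, only, known or untested is meant among the compounds shown, and "the series" means these compounds.

Compound 1 `OC[C@H]1OC(n2cnc3c(Nc4ccccc4)nccc32)[C@H](O)[C@@H]1O` was tested in a functional assay on EL4 cells (Mus musculus) for inhibition, tested at 100 uM (a lower number here means less inhibition, a higher number more inhibition at the concentration tested (going by the name of the read-out)), where compound 1 gives 10%; this is the only plain number among the two results shown. Compound 2 `[O-][n+]1ccc2c(c1)ncn2C1O[C@H](CO)[C@@H](O)[C@H]1O` sits at a limit of this assay, at which compound 2 gives < 5%. Compound 3 `CSc1nccc2c1ncn2C1O[C@H](CO)[C@@H](O)[C@H]1O` differs from compound 1 by methylsulfanyl in place of anilino on an aromatic carbon. Among the compounds with values here, no step between two measured compounds is available, so the size of the move is expected to stay within the scatter, with an expected step of a number 3 percentage points lower from compound 1 to compound 3 (within the scatter). Compound 3 is therefore estimated at 7%, between 0% and 16%, and may well be reported only as a limit.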

Compound 3, a percentage reported as inhibition, at one concentration (the size of the read-out at that concentration, not a potency): < 5%
Compound 3 gave a limit, no number (the forecaster's own chance of this, stated with the estimate: 45%); middle value at least 2 percentage points from the limit.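

In this assay, methylsulfanyl in place of anilino on the aromatic carbon next to the ring nitrogen gives a number at least 5 percentage points lower from compound 1 to compound 3 (that floor lies within the scatter). Within the data shown here, this is the first step at this position, and it shows that methylsulfanyl, which carries no ring and no hydrogen-bond donor, does not raise inhibition over anilino. Compound 3 is reported only as a limit, so the true size of the step cannot be read: the limit of < 5% in this assay, at which 2 of the 3 values shown sit.

As far as these compounds go, it stays open whether the step goes beyond the scatter. From the compounds shown here alone, it also stays open whether an amine or a benzylamino group on this carbon would read differently from anilino.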